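The source may hold more compounds than are shown below. What is called first, only, known or untested is meant among the compounds shown, and "the series" means these compounds.

Compound 1 `COc1ncc(-c2ccc3ncnc(N[C@H]4CCCN(C(=O)C5CCNCC5)C4)c3c2)cc1C#N` gives 2440 nM in a functional assay on SU-DHL-6 cells (Homo sapiens) for antiproliferative activity, read by MTT assay; on this read-out lower numbers stand for stronger inhibition and higher numbers for weaker inhibition.
Compound 2 `CCOC(=O)CN1CCC[C@H](Nc2ncnc3ccc(-c4cnc(OC)c(C#N)c4)cc23)C1` gives 500 nM in this assay.
Compound 3 `COc1ncc(-c2ccc3ncnc(N[C@H]4CCCN(C(=O)CN(C)C)C4)c3c2)cc1C#N` gives 160 nM in this assay.

Compound 2 stands second highest of the three numbers in this assay: the nearest is compound 3, with a 3.1-fold lower number from compound 2 to compound 3 (0.49 log units; beyond the scatter), and the furthest is compound 1, with a 4.9-fold lower number from compound 1 to compound 2 (0.69 log units; beyond the scatter). All three measured steps, including a 15-fold lower number from compound 1 to compound 3 (1.18 log units; beyond the scatter), alter the group on the amine nitrogen in the ring and leave the rest of the shared core untouched.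

Compound 4 `CCOC(=O)CN1CCC[C@H](Nc2ncnc3ccc(-c4cnc(OC)c(C(F)(F)F)c4)cc23)C1` differs from compound 2 elsewhere: trifluoromethyl in place of cyano on an aromatic carbon. No measured pair changes anything on that aromatic carbon, so none of the steps shown bears on this change, and there is no basis from these compounds for expecting a step beyond the scatter in either direction. The estimate therefore rests on compound 2 alone, with a wide range. Compound 4 is expected to give about 700 nM, within 200 nM to 2500 nM. The expected step is a 1.4-fold higher number from compound 2 to compound 4 (0.15 log units; within the scatter).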

Compound 4, half-maximal inhibitory concentration: 230 nM
Compound 4: the middle estimate sits 3.0-fold (0.48 log units) above what was measured, and the stated range covers the measured number.
By their numbers in this assay, from the lowest: compounds 3 and 4 (each within the scatter of the next); then compound 2; then compound 1.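

Among these compounds, the aromatic carbon that carries the nitrile in compound 2 is the first place outside the group on the ring amine nitrogen where a change can be read, and the change is not silent: in this assay, trifluoromethyl in place of cyano gives a 2.2-fold lower number from compound 2 to compound 4 (0.34 log units; beyond the scatter). The position therefore accepts trifluoromethyl, with four heavy atoms where cyano has two, and the cyano group is not required for activity on this read-out when (ethoxycarbonyl)methyl sits on the ring nitrogen. Nothing measured here accounts for the stronger inhibition, so no cause can be given for it.

Going by these compounds, whether the same exchange holds with the ((dimethylamino)methyl)carbonyl group of compound 3 remains open. Also open, on these data alone, is how a chlorine atom, an amine or a carboxylic acid would behave on this aromatic carbon.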